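Aryl swap at the carbon double-bonded to nitrogen

The compounds below may be only part of what the source reports. "The series", "measured", "known", "first", "only" and "open" are said of these compounds alone.

Measured so far, in a functional assay on MKN-45 cells (Homo sapiens) for cytotoxicity, read by MTT assay, with a stated time of 72 h; on this read-out higher numbers stand for weaker inhibition and lower numbers for stronger inhibition:
compound 1 `CN(C)CCn1cnnc1-c1cc(Oc2ccc(NC(=O)N/N=C/c3ccc(F)cc3)cc2F)ccn1` gives 1030 nM
compound 2 `CN(C)CCn1cnnc1-c1cc(Oc2ccc(NC(=O)N/N=C/c3ccc(F)cc3Cl)cc2F)ccn1` gives 870 nM

Compound 2 holds the lowest of the two numbers in this assay; the gap between the two is a 1.2-fold lower number from compound 1 to compound 2 (0.07 log units; within the scatter), so the two are not distinguished, and neither can be called the stronger.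

Compound 3 `COc1cc(/C=N/NC(=O)Nc2ccc(Oc3ccnc(-c4nncn4CCN(C)C)c3)c(F)c2)ccc1O` is not yet measured. Relative to compound 2 the change is 4-hydroxy-3-methoxyphenyl in place of 2-chloro-4-fluorophenyl on a carbon with a double bond to nitrogen.

For the measured compounds named here, the only measured step, a 1.2-fold lower number from compound 1 to compound 2 (0.07 log units; within the scatter), concerns a chloro in place of hydrogen on the same aryl and stays within the scatter. Going by the values given here, no step touches an exchange of a halogenated aryl for a hydroxy-methoxy aryl, so there is nothing on which to base a direction. The expectation for compound 3 in this assay is therefore a step of a 1.1-fold higher number from compound 2 to compound 3 (0.06 log units; within the scatter), no change beyond the scatter, with a wide band to cover the unknown.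

Compound 3 is estimated at 1000 nM, within 400 nM to 2500 nM.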

Compound 3, half-maximal inhibitory concentration: 3780 nM
Beside the measured number, compound 3's estimate is 3.8-fold (0.58 log units) below it; the whole stated range lies below it.
By their numbers in this assay, from the lowest: compounds 2 and 1 (each within the scatter of the next); then compound 3.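

On a carbon with a double bond to nitrogen, the aryl group does affect the number in this assay: 4-hydroxy-3-methoxyphenyl gives a 4.3-fold higher number from compound 2 to compound 3 (0.64 log units; beyond the scatter) and a 3.7-fold higher number from compound 1 to compound 3 (0.56 log units; beyond the scatter) against the two halogenated aryl groups. For the compounds shown here, the earlier pair showed only that adding chloro to the 4-fluorophenyl ring left compounds 1 and 2 within the scatter of each other, so this is the first step at this position that lies beyond the scatter, and it runs towards weaker inhibition in both comparisons. The step exchanges halogens for oxygen-bearing groups in a single move, and no measurement here bears on why the number rises.

The compounds shown leave open whether the hydroxy group, the methoxy group or the loss of the halogens accounts for the step, since all of these change together in compound 3. They also leave open how this position responds to a phenyl ring carrying only hydroxy or only methoxy, or to one carrying an amine or a carboxylic acid.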